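A few compounds are considered here, and "the series" means these few. Any claim that something is new, unique, unknown or untested is made for them only; others in the source may bear on it.

Compound 1 `CNC(=O)c1cc(Oc2ccc(C3=NNC(c4cccc(Br)c4)C3)cc2)ccn1` has the lower of the two numbers measured in a functional assay on A549 cells (Homo sapiens) for cytotoxicity, read by MTT assay, with a stated time of 72 h (on this read-out higher numbers stand for weaker inhibition and lower numbers for stronger inhibition), where compound 1 gives 2840 nM. Going by the values given here, compound 2 `CNC(=O)c1cc(Oc2ccc(C3=NNC(c4ccc(Cl)c(Cl)c4)C3)cc2)ccn1` gives 10700 nM, and the only measured step, a 3.8-fold higher number from compound 1 to compound 2 (0.58 log units; beyond the scatter), concerns a different change. Compound 3 `CNC(=O)c1cc(Oc2ccc(C3=NNC(c4ccc(Br)cc4)C3)cc2)ccn1` differs from compound 1 only in the position of the bromine: 4-bromophenyl in place of 3-bromophenyl on a saturated ring carbon. Among the compounds with values here, no measured step bears on this change, so the expectation for compound 3 is a step of about a 1.2-fold higher number from compound 1 to compound 3 (0.09 log units; within the scatter), within the scatter. Compound 3 is therefore estimated at 3500 nM, with a range from 1400 nM to 9000 nM.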

Compound 3, half-maximal inhibitory concentration: 21000 nM
Estimate against measurement, compound 3: 6.0-fold (0.78 log units) below; measured number above the stated range.
By their numbers in this assay, from the lowest: compound 1; then compounds 2 and 3 (each within the scatter of the next).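

Moving the bromine, with the same atoms in the group, is enough to change the result at this saturated ring carbon: 4-bromophenyl in place of 3-bromophenyl gives (a 7.4-fold higher number from compound 1 to compound 3 (0.87 log units; beyond the scatter)) in this assay. Putting 4-bromophenyl in place of 3,4-dichlorophenyl gives (a 2.0-fold higher number from compound 2 to compound 3 (0.29 log units; within the scatter)), so these two cannot be told apart here, while compound 1 stands apart from both. Nothing available explains the effect of moving the bromine.

The compounds shown leave open whether the 3-position favours bromine alone or also suits other groups, such as chlorine, a methoxy group or an amine.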